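The compounds below may be only part of what the source reports. "The series", "measured", "known", "first", "only" and "open" are said of these compounds alone.

Of the compounds shown here, three sharing one core have been measured in an assay on CHO cells with metabotropic glutamate receptor 2 (Homo sapiens) as the target, read by FLIPR; on this read-out lower numbers stand for an effect already at smaller amounts and higher numbers for an effect only at larger amounts of compound. Compound 1 `Cn1c(CN2CCN(c3ccc(Cl)cc3F)CC2)nc2ccccc21` gives 126 nM, compound 2 `Cn1c(CN2CCN(c3ccc(C(F)(F)F)cn3)CC2)nc2ccccc21` gives 501 nM, and compound 3 `Cn1c(CN2CCN(c3ccccc3F)CC2)nc2ccccc21` gives 794 nM. Compound 3 therefore stands at the top of the three numbers; its gap to compound 2 lies within the scatter, while the step of a 6.3-fold higher number from compound 1 to compound 3 (0.80 log units; beyond the scatter) shows how much weaker compound 3 is than compound 1.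

Compound 4 `Cn1c(CN2CCN(c3ccccn3)CC2)nc2ccccc21` differs from compound 3 in one place: pyridin-2-yl in place of 2-fluorophenyl on an amine nitrogen in a ring. Going by the values given here, no measured step matches this exchange. The step from compound 1 to compound 3 shows only that stripping a chloro from the ring at this position raised the number. Compound 2 carries a pyridine ring with a trifluoromethyl group and sits close to compound 3, which offers no direct guide for a bare pyridine. Compound 4 is therefore expected to move by a 2.5-fold higher number from compound 3 to compound 4 (0.40 log units; beyond the scatter) in this assay, toward a somewhat higher number, with an estimated value of 2000 nM and a range from 600 nM to 6000 nM.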

Compound 4, half-maximal effective concentration: 15800 nM
Compound 4: the middle estimate sits 7.9-fold (0.90 log units) below what was measured; measured number outside the range, above it.
By their numbers in this assay, from the lowest: compound 1; then compounds 2 and 3 (each within the scatter of the next); then compound 4.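

Replacing 2-fluorophenyl with pyridin-2-yl on the amine nitrogen gives a 20-fold higher number from compound 3 to compound 4 (1.30 log units; beyond the scatter) in this assay, so this position tolerates this exchange poorly. The bare pyridin-2-yl ring also depends strongly on what it carries: hydrogen in place of trifluoromethyl gives a 32-fold higher number from compound 2 to compound 4 (1.50 log units; beyond the scatter), and replacing the 4-chloro-2-fluorophenyl of the best compound here with pyridin-2-yl gives a 130-fold higher number from compound 1 to compound 4 (2.10 log units; beyond the scatter). Nothing available explains why these numbers rise so steeply.

From the compounds shown here alone, the exchange from compound 3 to compound 4 removes the fluorine and brings in a ring nitrogen at once, so the share of each in the rise stays open. Also open, going by these compounds, is how a pyridin-2-yl ring carrying chloro, methoxy or an amine would compare with the one carrying trifluoromethyl.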